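A few compounds are considered here, and "the series" means these few. Any claim that something is new, unique, unknown or untested is made for them only; others in the source may bear on it.

Compound 1, `N=C(N)NCCC[C@H](NC(=O)CN(c1nc(Cl)nc2[nH]cnc12)C1CC1)C(=O)OCc1ccccc1`, gives 10.2% in a functional assay on the whole organism (Tail, strain ICR) with Mus musculus as the target, in the tail flick test, with a stated time of 120 min, at a dose of 25 umol/kg by the oral route; on this read-out higher numbers stand for a stronger effect at the one dose given and lower numbers for a weaker effect.
Compound 2, `O=C(O)CC[C@H](NC(=O)CN(c1nc(Cl)nc2[nH]cnc12)C1CC1)C(=O)O`, gives 30.1% in this assay.
Compound 3, `O=C(O)C[C@H](NC(=O)CN(c1nc(Cl)nc2[nH]cnc12)C1CC1)C(=O)O`, gives 22% in this assay.

All three share the same core and the same amide linker; they differ only in the group carried on the saturated chain carbon bound to an amide-type nitrogen and a carbonyl carbon. Of the three numbers, compound 1 gives the lowest: compound 3 stands beyond the scatter above it, and compound 2 further above still.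

Compound 4, `C[C@@H](O)[C@H](NC(=O)CN(c1nc(Cl)nc2[nH]cnc12)C1CC1)C(=O)OCc1ccccc1`, has not yet been measured. It differs from compound 1 at one place: a group of 3 heavy atoms (2 carbon, 1 oxygen; no ring) in place of a group of 7 heavy atoms (4 carbon, 3 nitrogen; no ring), on a saturated chain carbon bound to an amide-type nitrogen and a carbonyl carbon. The group that enters is 1-hydroxyethyl, with one defined stereocentre, and it sits on the same chain carbon where compounds 2 and 3 carry their own groups.

Going by the values given here, only one measured step changes a group at that position: a number 8.1 percentage points lower from compound 2 to compound 3 (within the scatter). Among the compounds with values here, that step lies within the scatter, so the one comparison available gives no sign that a change at this carbon moves the number far. The change to compound 4 is of a different kind, a group with three donors leaving and one entering, so the guide is loose. Compound 4 is therefore expected to give 15%, with a range from 2% to 32%. This estimate means a step of a number 4.8 percentage points higher from compound 1 to compound 4 (within the scatter), expected to stay within the scatter.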

Compound 4, a percentage reported as activity, at one dose (the size of the read-out at that dose, not a potency): 30.7%
The estimate for compound 4 lay 15.7 percentage points below the measured number; the measured number falls inside the stated range.
By their numbers in this assay, from the lowest: compound 1; then compounds 3, 2 and 4 (each within the scatter of the next).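

The step of a number 20.5 percentage points higher from compound 1 to compound 4 (beyond the scatter) shows that, with the benzyl ester kept in place, the group on this saturated chain carbon can move the number in this assay beyond the scatter, which the earlier step at this carbon, a number 8.1 percentage points lower from compound 2 to compound 3 (within the scatter), did not show. This change replaces the group of 7 heavy atoms with the much smaller 1-hydroxyethyl, so size, atom types and hydrogen-bond donors all differ at once, and this single step cannot separate their contributions. No measurement here explains why the number differs between these two compounds.

Going by these compounds, it remains open whether a plain ethyl or hydroxymethyl group on this carbon would give a number close to that of compound 4, which would help show whether the hydroxyl or the small size of the group matters more. The opposite configuration at the stereocentre of 1-hydroxyethyl is also an open question, and a single dose cannot show how potency would compare across a range of doses.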